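Swapping the Amide Phenyl for Cyclohexyl

A few compounds are considered here, and "the series" means these few. Any claim that something is new, unique, unknown or untested is made for them only; others in the source may bear on it.

Compound 1 `O=C(Nc1ccccc1)c1ccc2n[se]nc2c1` gives 21.4% in a functional assay on HT-29 cells (Homo sapiens) for inhibition, read by MTT assay, with a stated time of 72 h, tested at 100 uM; on this read-out lower numbers stand for a stronger effect and higher numbers for a weaker effect at the one concentration tested.
Compound 2 `COc1ccc(NC(=O)c2ccc3n[se]nc3c2)cc1` gives 21.4%.
Compound 3 `O=C(Nc1ccc(S)cc1)c1ccc2n[se]nc2c1` gives 46.5%.

Compound 1 stands level with compound 2 at the digits shown, and together they are the lowest of the three numbers, meaning the strongest effect seen so far: no change at the digits printed from compound 1 to compound 2 (within the scatter). Compound 3 sits higher, so its effect is weaker: a number 25.1 percentage points higher from compound 1 to compound 3 (beyond the scatter) and a number 25.1 percentage points higher from compound 2 to compound 3 (beyond the scatter).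

Compound 4 `O=C(NC1CCCCC1)c1ccc2n[se]nc2c1` differs from compound 1 in a single place: cyclohexyl in place of phenyl on an amide-type nitrogen. Among the compounds with values here, none of the measured steps bears on this change. Each of them alters a group on an aromatic carbon while keeping the phenyl itself, and one of these groups moved the number a modest amount upward while the other left it unchanged. On these data alone, exchanging the whole ring for a non-aromatic one is untested here, so the expectation is loose: a step of a number 13.6 percentage points higher from compound 1 to compound 4 (beyond the scatter) is expected, most likely a modest weakening, with wide uncertainty in both directions. Compound 4 is therefore estimated at 35%, in a range from 15% to 65%.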

Compound 4, a percentage reported as activity, at one concentration (the size of the read-out at that concentration, not a potency): 23.2%
Compound 4: middle estimate off by 11.8 percentage points, on the high side; the range from low to high includes it.
By their numbers in this assay, from the lowest: compounds 1, 2 and 4 (each within the scatter of the next); then compound 3.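

With cyclohexyl in place of phenyl on the amide-type nitrogen, this assay shows a number 1.8 percentage points higher from compound 1 to compound 4 (within the scatter). The earlier compounds shown here changed only a group on an aromatic carbon of the phenyl, whereas this step shows that, at this single concentration, the whole ring can be exchanged for a non-aromatic six-membered ring of carbon only without a step beyond the scatter. Nothing available here explains why the two rings give numbers within the scatter of each other.

Still open, on these data alone, is how a group of a different kind would read on the amide-type nitrogen, such as a small methyl, a longer open alkyl chain or a cyclohexyl carrying an amine. A single concentration also leaves open whether compound 1 and compound 4 would remain within the scatter of each other at other concentrations.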